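The source may hold more compounds than are shown below. What is called first, only, known or untested is meant among the compounds shown, and "the series" means these compounds.

Working notes on the series in a functional assay on M14 cells (Homo sapiens) for inhibition, read by sulforhodamine B assay, with a stated time of 48 h, tested at 10 uM; on this read-out lower numbers stand for less inhibition of growth and higher numbers for more inhibition of growth at the one concentration tested. Among the compounds with values here, compound 1 (`COc1ccc(-c2nc3sc(-c4ccccc4)cn3n2)cc1`) gives 71%, the higher of the two numbers so far. Compound 2 (`COc1cc(-c2nc3sc(-c4ccccc4)cn3n2)cc(OC)c1OC`) gives 25%, and this gap lies beyond the scatter.

Compound 3 (`c1ccc(-c2nc3sc(-c4ccccc4)cn3n2)cc1`) has not yet been measured. It follows from compound 1 by one change: hydrogen in place of methoxy on an aromatic carbon, with hydrogen in place of methoxy on an aromatic carbon, para to a large group. Within the data shown here, no measured pair isolates this change, so the expectation rests on thin ground. Compound 1 at 71% holds the top number, and a fall in this assay is therefore thought more likely than a rise, probably moderate in size and beyond the scatter. The expected move is a number 21 percentage points lower from compound 1 to compound 3 (beyond the scatter). For compound 3 the estimated value is 50%, with an expected range of 22% to 78%.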

Compound 3, percent growth inhibition at one concentration: 13%
Compound 3: the middle estimate sits 37 percentage points above what was measured, and the stated range ends above it.
By their numbers in this assay, from the lowest: compound 3; then compound 2; then compound 1.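

Hydrogen in place of methoxy on an aromatic carbon, para to a large group, gives a number 58 percentage points lower from compound 1 to compound 3 (beyond the scatter) in this assay. Within the data shown here, this is the first pair that isolates a single change, and it shows that the read-out at the one concentration tested is highly sensitive to what sits at this place on the shared core. No measurement at hand gives a reason for the size of this step.

As far as these compounds go, whether the number of compound 1 depends on methoxy itself or would also be reached with another group at this place, such as hydroxyl, ethoxy, an amine or a chlorine atom, stays open. A single pair also leaves open whether the same change would give a step of similar size elsewhere in the series.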